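A few compounds are considered here, and "the series" means these few. Any claim that something is new, unique, unknown or untested is made for them only; others in the source may bear on it.

Measured compounds:
compound 1, `CCCSc1nc(N[C@@H]2C[C@H]2c2cccnc2)c2nnn([C@@H]3C[C@H](OCCO)[C@@H](O)[C@H]3O)c2n1`, 1520 nM
compound 2, `CCCSc1nc(N[C@@H]2C[C@H]2c2ccc(F)c(F)c2)c2nnn([C@H]3[C@H](O)[C@H](O)[C@@H](OCCO)[C@@H]3O)c2n1`, 1380 nM

In an assay on a cell-free system (plasma) for antagonist activity at P2Y purinoceptor 12 (Rattus norvegicus), with a stated time of 5 min (a higher number here means a weaker inhibitor, a lower number a stronger inhibitor), compound 1 gives 1520 nM, and in this assay compound 2 gives 1380 nM. Compound 2 shows the lower of the two numbers, but the gap to compound 1 falls within the scatter, so the two compounds cannot be told apart on these data.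

Compound 3, `CCCSc1nc(N[C@@H]2C[C@H]2c2ccc(F)c(F)c2)c2nnn([C@@H]3C[C@H](F)[C@@H](O)[C@H]3O)c2n1`, has not been measured. It differs from compound 2 in one place: 4-fluoro-2,3-dihydroxycyclopentyl in place of 2,4,5-trihydroxy-3-(2-hydroxyethoxy)cyclopentyl on an aromatic nitrogen. Within the data shown here, no step between two measured compounds speaks to this kind of change, so there is nothing in the numbers to lean on. On the size of the group that leaves against the one that enters, a step toward a higher number is expected, of modest size, and it may or may not exceed the scatter. For compound 3 the estimate is 3000 nM, with a range from 800 nM to 12000 nM, which means an expected step of a 2.2-fold higher number from compound 2 to compound 3 (0.34 log units; beyond the scatter).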

Compound 3, half-maximal inhibitory concentration: 110 nM
Beside the measured number, compound 3's estimate is 27-fold (1.44 log units) above it; measured number below the stated range.
By their numbers in this assay, from the lowest: compound 3; then compounds 2 and 1 (each within the scatter of the next).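

In this assay, among these compounds, replacing 2,4,5-trihydroxy-3-(2-hydroxyethoxy)cyclopentyl with 4-fluoro-2,3-dihydroxycyclopentyl on the aromatic nitrogen gives a 13-fold lower number from compound 2 to compound 3 (1.10 log units; beyond the scatter), the first one-place step to show that the group at this position can shift the number well beyond the scatter. The entering group is the smaller of the two, with fewer hydrogen-bond donors and acceptors, so the larger, more heavily hydroxylated ring substituent is not required for a lower number in this series. Nothing measured here accounts for the size of the step.

The change alters several features at once, leaving open whether the gain follows from the fluorine, the missing 2-hydroxyethoxy chain or the missing hydroxyl groups. Going by these compounds, it also remains open how a single hydroxyl, a methoxy group or a plain hydrogen in place of the fluorine would read.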